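The source may report more compounds than this note shows. Statements on the series, on what has been measured and on what is new or still open speak of the compounds shown alone.

Measured so far in a functional assay on A549 cells (Homo sapiens) for cytotoxicity; on this read-out higher numbers stand for weaker inhibition and lower numbers for stronger inhibition:
Compound 1 `C=C/C=C\[C@H](C)[C@H](OC(N)=O)[C@@H](C)[C@H](O)[C@@H](C)C/C(C)=C\[C@H](C)[C@@H](O)[C@@H](C)/C=C\CCc1ccccc1` gives 510 nM.
Compound 2 `C=C/C=C\[C@H](C)[C@H](OC(N)=O)[C@@H](C)[C@H](O)[C@@H](C)C/C(C)=C\[C@H](C)[C@@H](O)[C@@H](C)/C=C\CCc1cccc(O)c1` gives 190 nM.

Among the measured compounds shown here, compound 2 stands at the lowest of the two numbers in this assay; its nearest neighbour is compound 1, and the single counted step a 2.7-fold lower number from compound 1 to compound 2 (0.43 log units; beyond the scatter) separates them. Compound 3 `C=C/C=C\[C@H](C)[C@H](OC(N)=O)[C@@H](C)[C@H](O)[C@@H](C)C/C(C)=C\[C@H](C)[C@@H](O)[C@@H](C)/C=C\CCc1ccsc1` differs from compound 2 as follows: thiophen-3-yl in place of 3-hydroxyphenyl on a saturated chain carbon, two bonds along the chain from a double-bonded chain carbon. For the measured compounds named here, the only measured step bearing on this change is the one from compound 1 to compound 2, which reads a 2.7-fold lower number from compound 1 to compound 2 (0.43 log units; beyond the scatter) and concerns the hydroxy that is now lost again, while nothing measured speaks to the thiophen-3-yl itself. The loss of the hydroxy is therefore expected to undo much of that gain, so the step of a 2.4-fold higher number from compound 2 to compound 3 (0.37 log units; beyond the scatter) is expected to run toward a higher number, probably beyond the scatter. For compound 3 in this assay the estimate is 450 nM, within a range from 150 nM to 1500 nM.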

Compound 3, half-maximal inhibitory concentration: 4000 nM
Estimate against measurement, compound 3: 8.9-fold (0.95 log units) below; measured number outside the range, above it.
By their numbers in this assay, from the lowest: compound 2; then compound 1; then compound 3.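

In this assay the aromatic group at the end of the chain proves to matter beyond its hydroxy: thiophen-3-yl in place of 3-hydroxyphenyl gives a 21-fold higher number from compound 2 to compound 3 (1.32 log units; beyond the scatter), a far larger change than a 2.7-fold lower number from compound 1 to compound 2 (0.43 log units; beyond the scatter). Loss of the hydroxy alone does not describe the result, since thiophen-3-yl in place of phenyl, with no hydroxy on either side, still gives a 7.8-fold higher number from compound 1 to compound 3 (0.89 log units; beyond the scatter), leaving compound 3 the weakest of the three. Nothing available explains why the thiophen-3-yl ring fares worse than either six-membered ring.

The compounds shown leave open whether other five-membered rings, such as thiophen-2-yl or furan-3-yl, behave like thiophen-3-yl. They also leave open whether a methoxy or an amine on the phenyl ring would match the gain seen with the hydroxy.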